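Methoxy added to a second aryl ring in a chalcone series

The source may hold more compounds than are shown below. What is called first, only, known or untested is meant among the compounds shown, and "the series" means these compounds.

Compound 1 `COc1ccc(-c2cc(C(=O)/C=C/c3ccccc3)nc3cc(-c4ccccc4)nn23)cc1OC` gives 23300 nM in a functional assay on MDA-MB-231 cells (Homo sapiens) for antiproliferative activity, read by MTT assay, with a stated time of 24 h; on this read-out lower numbers stand for stronger inhibition and higher numbers for weaker inhibition. Compound 2 `COc1cc(-c2cc(C(=O)/C=C/c3ccccc3)nc3cc(-c4ccccc4)nn23)cc(OC)c1OC` differs from it by methoxy in place of hydrogen on an aromatic carbon, and in this assay compound 2 gives 19200 nM; the step is a 1.2-fold lower number from compound 1 to compound 2 (0.08 log units; within the scatter). Compound 3 `COc1ccc(C(=O)/C=C/c2cc(-c3ccc(OC)c(OC)c3)n3nc(-c4ccccc4)cc3n2)cc1` differs from compound 1 by 2-((4-methoxyphenyl)carbonyl)ethenyl in place of (2-phenylethenyl)carbonyl on an aromatic carbon, and in this assay compound 3 gives 13900 nM, a step of a 1.7-fold lower number from compound 1 to compound 3 (0.22 log units; within the scatter). All three numbers lie within the usual scatter of one another.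

Compound 4 `COc1ccc(C(=O)/C=C/c2cc(-c3ccc(OC)c(OC)c3)n3nc(-c4ccccc4)cc3n2)cc1OC` is not yet measured. It differs from compound 3 by methoxy in place of hydrogen on an aromatic carbon. This is the same kind of change as that from compound 1 to compound 2, though the surroundings are not identical: in compound 1 the place is also meta to a methoxy group, whereas in compound 3 it is ortho to a methoxy group and meta to a large group only. Because the earlier step was a 1.2-fold lower number from compound 1 to compound 2 (0.08 log units; within the scatter), the step from compound 3 to compound 4 is expected to be about a 1.2-fold lower number from compound 3 to compound 4 (0.06 log units; within the scatter). Compound 4 is therefore estimated at 12000 nM, with a likely range from 6000 nM to 25000 nM.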

Compound 4, half-maximal inhibitory concentration: 2600 nM
Compound 4: middle estimate off by 4.6-fold (0.66 log units), on the high side; measured number below the stated range.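

In this assay, methoxy in place of hydrogen on an aromatic carbon, turning a (4-methoxyphenyl)carbonyl group into a (3,4-dimethoxyphenyl)carbonyl group, gives a 5.3-fold lower number from compound 3 to compound 4 (0.73 log units; beyond the scatter). Set beside the same change on the core of compound 1, this step does not have the same size: the same change on two cores in this assay, a 1.2-fold lower number (0.08 log units; within the scatter) from compound 1 to compound 2 and a 5.3-fold lower number (0.73 log units; beyond the scatter) from compound 3 to compound 4, 4.4-fold (0.64 log units) apart, beyond the scatter of two such steps The change therefore cannot be carried from one core to the other in this series as a fixed step, but two pairs in one assay do not show what sets the steps apart, whether the core itself or the different surroundings of the new methoxy group.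

The compounds shown leave open whether a hydroxy group, an amine or a longer chain such as ethoxy at the same place on compound 3 would give a step like that of methoxy. They also leave open whether the step to compound 4 would recur on other cores carrying the same (3,4-dimethoxyphenyl)carbonyl group.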